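Adding a Second Chloro to a Piperazine Phenyl Ring

This account rests on a few compounds, and the source may have more. Where it says the series, first, only, none or still open, it means among the compounds named here.

Compound 1 `CC1(c2ccccc2)CC(=O)N(CC(=O)N2CCN(c3ccc(Cl)cc3)CC2)C1=O` and compound 2 `CC1(c2ccccc2)CC(=O)N(CC(=O)N2CCN(c3ccccc3Cl)CC2)C1=O` share one core and differ only in where a chloro group sits on the phenyl ring attached to the amine nitrogen of the ring. In a functional assay on the whole organism (strain CD-1) with Mus musculus as the target, with a stated time of 2 h (a higher number here means that more compound is needed for the effect, a lower number that less compound is needed), compound 1 gives 300 mg/kg, while compound 2 gives 100 mg/kg; this is a 3.0-fold lower number from compound 1 to compound 2 (0.48 log units; beyond the scatter). On these two numbers compound 2 stands lowest. Compound 3 `CC1(c2ccccc2)CC(=O)N(CC(=O)N2CCN(c3cccc(Cl)c3Cl)CC2)C1=O` is not yet measured. Relative to compound 2 it differs by chloro in place of hydrogen on an aromatic carbon, the new chloro sitting ortho to a chloro group and meta to a large group. Within the data shown here, no measured step adds a chloro group, so the one step seen, the move of a chloro from one position to another, only loosely bears on this change. Compound 3 is therefore expected to stay near compound 2, with an estimated step of no change at the digits printed from compound 2 to compound 3 (within the scatter), giving an expected 100 mg/kg with a range from 30 mg/kg to 300 mg/kg.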

Compound 3, minimum effective dose: "not active" (no number reported)
No number was reported for compound 3, and the estimate cannot be compared.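

In this assay, among these compounds, compound 3 is reported as "not active" with no number, so no step from compound 2 to compound 3 can be read. Nothing available accounts for this result. Going by these compounds, how far the 2,3-dichlorophenyl group shifts the dose needed stays open.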